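The compounds below may be only part of what the source reports. "The series", "measured", "known", "first", "only" and "open" are said of these compounds alone.

Measured so far in an ADME assay on Chem1 cells (Homo sapiens) for cytotoxicity; on this read-out higher numbers stand for lower toxicity in this test and lower numbers for higher toxicity in this test (each entry is a limit of the assay, not a number):
- compound 1 `NCCCCN(C[C@@H]1CN(C(=O)c2ccco2)CCN1)[C@H]1CCCc2cccnc21` gives > 10 uM as its limit
- compound 2 `NCCCCN(C[C@@H]1CN(C(=O)OCc2ccccc2)CCN1)[C@H]1CCCc2cccnc21` gives > 10 uM as its limit
- compound 3 `NCCCCN(C[C@H]1CNCCN1)[C@H]1CCCc2cccnc21` gives > 10 uM as its limit

Compound 3 therefore stands at the limit > 10 uM and has no exact reading. Compound 4 `NCCCCN(C[C@@H]1CNCCN1)[C@H]1CCCc2cccnc21` is not yet measured, and its structural change from compound 3 reads the two compounds have the same atoms and bonds and differ only in configuration as drawn: 1 of 2 stereo elements differ; a stereocentre at a saturated ring carbon is drawn R in compound 3 and S in compound 4 with nothing further to add.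

Within the data shown here, the one measured step is a step that the two limits leave unreadable from compound 1 to compound 2 and it concerns benzyloxy in place of furan-2-yl on a carbonyl carbon. It is not a change of configuration and gives no size to carry over. Among the measured compounds shown here, no measured pair differs in configuration alone.

For the measured compounds named here, compound 4 is expected to be reported in the same way because the limit of > 10 uM in this assay, at which 3 of the 3 values shown sit, and no measured compound gives a number. The expected size is a step that the limit leaves unreadable from compound 3 to compound 4 as an estimate, with no change beyond the usual scatter expected in either direction in this assay for this pair. For compound 4 the estimate is 15 uM with an expected range from 7 uM to 40 uM in this read-out.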

Compound 4, half-maximal toxic concentration: > 10 uM
Compound 4: no number, only a limit; the forecaster's own chance of this, stated with the estimate: 80%; the middle value does not contradict the limit.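

In this assay compound 4 gives > 10 uM as a limit of the assay and not a number. No new step can be read between compound 4 and compound 1, compound 2 or compound 3. The compounds shown leave open whether the configuration at the saturated ring carbon alters the half-maximal toxic concentration.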